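Pyrrole in place of pyridine on the amide aryl

The source may report more compounds than this note shows. Statements on the series, on what has been measured and on what is new or still open speak of the compounds shown alone.

Among the compounds with values here, the two measured members share one core: compound 1 is `O=C(Nc1ccc2scnc2c1)C1CCCN(Cc2ccc(F)c(F)c2)C1` and compound 2 is `O=C(Nc1ccc(-c2ccccn2)cc1)C1CCCN(Cc2ccc(F)c(F)c2)C1`. Activity is followed in a functional assay on A-375 cells (Homo sapiens) for activation, with a stated time of 3 days; on this read-out lower numbers stand for an effect already at smaller amounts and higher numbers for an effect only at larger amounts of compound. Compound 1 gives only a limit there, > 20000 nM, so no number is known for it. In this assay, within the data shown here, compound 2 gives 11000 nM, the only actual number among the values shown. The remaining entry is a limit (the limit of > 20000 nM in this assay, at which 1 of the 2 values shown sits). Among the measured compounds shown here, since no two measured compounds differ in a single place, no measured step is available to anchor an expectation.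

Compound 3 is `O=C(Nc1ccc(-c2ccc[nH]2)cc1)C1CCCN(Cc2ccc(F)c(F)c2)C1`. It differs from compound 2 by 1H-pyrrol-2-yl in place of pyridin-2-yl on an aromatic carbon. For the measured compounds named here, with no measured step to lean on, the expected step from compound 2 to compound 3 in this assay is small, a 1.4-fold higher number from compound 2 to compound 3 (0.13 log units; within the scatter), and is not expected to exceed the usual scatter in either direction. Compound 3 is therefore estimated at 15000 nM in this assay, with a range from 5000 nM to 40000 nM, and a real chance that only a limit is returned.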

Compound 3, half-maximal effective concentration: 720 nM
Estimate against measurement, compound 3: 21-fold (1.32 log units) above, outside the stated range (below it).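

In this assay, within the data shown here, 1H-pyrrol-2-yl in place of pyridin-2-yl on an aromatic carbon gives a 15-fold lower number from compound 2 to compound 3 (1.18 log units; beyond the scatter), the first step that can be read between compounds differing in one place, and it shows that the group on this carbon, para to a large group, strongly affects the read-out. The exchange alters several things at once: a six-membered aromatic ring with a hydrogen-bond acceptor leaves, and a five-membered aromatic ring with a hydrogen-bond donor enters, so this single step cannot separate ring size from the donor and acceptor counts. Nothing measured here gives a cause for the step.

Open, on these data alone, is which of these differences matters, a question that furan-2-yl, thiophen-2-yl or a pyrrole with a methyl group on its nitrogen would address at the same carbon. Also open, as far as these compounds go, is whether the step holds when the shared core is changed elsewhere, for instance by an added amine or carboxylic acid.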